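Removing the Hydroxy from Compound 3: An Expected Weak Inhibitor

The source may report more compounds than this note shows. Statements on the series, on what has been measured and on what is new or still open speak of the compounds shown alone.

The series shares one core, seen in compound 1 `C=C1C(=O)[C@H]2C[C@]1(O)CC1=C2[C@]2(C)CCCC(C)(C)[C@H]2CC1`, which in a functional assay on SK-OV-3 cells (Homo sapiens) for cytotoxicity, read by MTT assay, with a stated time of 24 h (a higher number here means a weaker inhibitor, a lower number a stronger inhibitor), gives 2900 nM. Compound 2 `C=C1C(=O)[C@H]2C[C@]1(O)CC1=C2[C@]2(C)CCC[C@](C)(CO)[C@H]2CC1` carries a hydroxymethyl on the saturated ring and was not determined in this assay, so its value is absent "not determined" (no result reported). Compound 3 `C[C@@H]1C(=O)[C@H]2C[C@]1(O)CC1=C2[C@]2(C)CCC[C@](C)(CO)[C@H]2CC1` keeps that hydroxymethyl but carries a methyl where compound 1 has an exocyclic methylene. In this assay compound 3 reaches only the limit of the assay, reported as > 50000 nM; this is a limit, not a number, and it is the position noted as the limit of > 50000 nM in this assay, at which 1 of the 3 values shown sits. Compound 3 therefore stands at the weak end of what is shown, with nothing beyond a limit to place it more exactly.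

Compound 4 `C[C@@H]1C(=O)[C@H]2C[C@]1(O)CC1=C2[C@]2(C)CCCC(C)(C)[C@H]2CC1` differs from compound 3 by one change, (hydrogen in place of hydroxy on a saturated chain carbon bound to a saturated ring carbon). No measured step of this kind is available among these compounds. The account expects the step of an at least 1.2-fold lower number from compound 3 to compound 4 (0.09 log units; that floor lies within the scatter) to stay within the scatter, with no clear direction. Compound 4 is thus expected to give about 40000 nM in this assay, with a range from 10000 nM to 150000 nM, and a fair chance that only a limit is reported.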

Compound 4, half-maximal inhibitory concentration: > 50000 nM
Compound 4: a limit, no number; the forecaster's own chance of this, stated with the estimate: 50%; at least 1.2-fold (0.09 log units) between middle value and limit.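

Compound 3 and compound 4 each give only a limit, not a number, in this assay, so no step between them can be read: the limit of > 50000 nM in this assay, at which 2 of the 4 values shown sit.

The compounds shown leave open whether hydrogen in place of hydroxy at this place changes the cytotoxicity at all.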